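A few compounds are considered here, and "the series" means these few. Any claim that something is new, unique, unknown or untested is made for them only; others in the source may bear on it.

Measured so far:
compound 1 `O=C(O)CCCCN(Cc1ccccc1)Cc1ccc2ccccc2c1`, in an assay on HEK293 cells for binding affinity to Substance-K receptor (Rattus norvegicus), read by FRET, tested at 10 uM (on this read-out lower numbers stand for less inhibition and higher numbers for more inhibition at the one concentration tested (going by the name of the read-out)), compound 1 gives 0%
compound 2 `O=C(CN(Cc1ccccc1)Cc1ccc2ccccc2c1)N1CCCCC1`, in this assay compound 2 gives 0%

Compound 2 stands level with compound 1 at the digits shown; the only measured step, no change at the digits printed from compound 1 to compound 2 (within the scatter), lies within the scatter. Compound 3 `c1ccc(CN(Cc2ccc3ccccc3c2)c2cccnc2)cc1` differs from compound 2 as pyridin-3-yl in place of ((piperidin-1-yl)carbonyl)methyl on an amine nitrogen. For the measured compounds named here, no measured step concerns the amine nitrogen itself, so none bears directly on this change. With both measured compounds at zero, the expected step of a number 2 percentage points higher from compound 2 to compound 3 (within the scatter) is none beyond the scatter. Compound 3 is estimated at 2%, range -8% to 20%.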

Compound 3, a percentage reported as inhibition, at one concentration (the size of the read-out at that concentration, not a potency): 0%
Beside the measured number, compound 3's estimate is 2 percentage points above it; the measured number falls inside the stated range.
By their numbers in this assay, from the lowest: compounds 1, 2 and 3 (each within the scatter of the next).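

On the amine nitrogen, pyridin-3-yl in place of ((piperidin-1-yl)carbonyl)methyl gives no change at the digits printed from compound 2 to compound 3 (within the scatter) in this assay and pyridin-3-yl in place of 4-carboxybutyl gives no change at the digits printed from compound 1 to compound 3 (within the scatter) in this assay as well. An aromatic ring set directly on this nitrogen therefore reads the same as the two chain groups. No supporting data explain this result.

With all three compounds at the same reading, nothing separates these groups at this concentration. Still open, as far as these compounds go, is whether another group on this nitrogen, such as a primary amine on a longer chain or a sulfonamide, would give any inhibition.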